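Adding a Methoxy Group to an Anilide Antagonist

The compounds below may be only part of what the source reports. "The series", "measured", "known", "first", "only" and "open" are said of these compounds alone.

The measured compounds:
- compound 1, `COc1ccc(Cl)cc1NC(=O)Cc1nn(CC(=O)O)c(=O)c2ccccc12`, 1190 nM
- compound 2, `O=C(Cc1nn(CC(=O)N2CCOCC2)c(=O)c2ccccc12)Nc1ccc(OC(F)(F)F)c(Cl)c1`, 103 nM
- compound 3, `O=C(O)Cn1nc(Cc2nc3cc(Cl)c(OCC(F)F)cc3[nH]2)c2ccccc2c1=O`, 15 nM

All three were tested in a functional assay on CHO cells for antagonist activity at sphingosine 1-phosphate receptor 2 (Homo sapiens), read by GTPgammaS binding; on this read-out higher numbers stand for weaker inhibition and lower numbers for stronger inhibition. Compound 1 gives the highest number of the three in this assay, so it is the weakest inhibitor shown; compound 2 gives a number that is beyond the usual scatter lower, and compound 3 gives the lowest number, also beyond the scatter.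

Compound 4, `COc1cc(OC)c(NC(=O)Cc2nn(CC(=O)O)c(=O)c3ccccc23)cc1Cl`, has not yet been measured. It differs from compound 1 in one place: methoxy in place of hydrogen on an aromatic carbon. Within the data shown here, no measured pair here shows this particular change, so its effect cannot be read from the data. Compounds 2 and 3 carry different groups on the aromatic ring and differ elsewhere too, so they do not settle the matter.

The step from compound 1 to compound 4 in this assay is expected to be small, most likely within the scatter, with a slight lean toward a lower number: a 1.5-fold lower number from compound 1 to compound 4 (0.17 log units; within the scatter). Compound 4 is therefore estimated at 800 nM in this assay, within a range from 250 nM to 2500 nM.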

Compound 4, half-maximal inhibitory concentration: 464 nM
Compound 4: the middle estimate sits 1.7-fold (0.24 log units) above what was measured; the measured number falls inside the stated range.
By their numbers in this assay, from the lowest: compound 3; then compound 2; then compound 4; then compound 1.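

Putting a methoxy group on this aromatic carbon, ortho to a chloro group and para to a large group, gives a 2.6-fold lower number from compound 1 to compound 4 (0.41 log units; beyond the scatter) in this assay. Among these compounds, this is the first direct reading of the change, as no earlier pair differed in this one place, and it shows that this carbon can carry the added group while the number moves toward stronger inhibition. The data offer no measured explanation for this shift.

The compounds shown leave open whether an ethoxy group, a fluoro group or an amine on the same carbon would lower the number further or raise it. They also leave open whether adding methoxy at this place would produce a similar step on the core of compound 3.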